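Trifluoromethoxy on a growth inhibitor with a methyl-bearing core

This account rests on a few compounds, and the source may have more. Where it says the series, first, only, none or still open, it means among the compounds named here.

Compound 1 `FC(F)(F)Oc1ccc(-c2ccc(-c3ccc(-c4nc5ccccc5[nH]4)cc3)cc2)cc1`: 100000 nM
Compound 2 `Cc1ccc2[nH]c(-c3ccc(-c4ccc(-c5ccccc5)cc4)cc3)nc2c1`: 3310 nM

Both compounds were tested in a functional assay on Gurav cells (Homo sapiens) for inhibition, read by sulforhodamine B assay; a lower number here means a stronger inhibitor of growth, a higher number a weaker inhibitor of growth. Compound 2 holds the lower of the two numbers, which makes it the stronger inhibitor of growth, and compound 1 lies well beyond the scatter above it. Going by the values given here, no pair of measured compounds differs in just one place, so no measured step is available as a guide.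

Compound 3 `Cc1ccc2[nH]c(-c3ccc(-c4ccc(-c5ccc(OC(F)(F)F)cc5)cc4)cc3)nc2c1` differs from compound 2 in one place: trifluoromethoxy in place of hydrogen on an aromatic carbon. Trifluoromethoxy takes the place of hydrogen on an aromatic carbon, para to a large group.

The nearest evidence is compound 1, which also carries trifluoromethoxy and gives 100000 nM. It differs from compound 2 elsewhere too, so this is only a weak hint. In this assay a moderate move towards weaker inhibition is expected, probably beyond the scatter but smaller than the gap between the two measured compounds. The expected step is a 3.0-fold higher number from compound 2 to compound 3 (0.48 log units; beyond the scatter). For compound 3 the estimated value is 10000 nM, with an expected range of 2000 nM to 60000 nM.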

Compound 3, concentration for 50% growth inhibition: 11000 nM
Compound 3: middle estimate off by 1.1-fold (0.04 log units), on the low side, and the stated range covers the measured number.
By their numbers in this assay, from the lowest: compound 2; then compound 3; then compound 1.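

In this assay, going by these compounds alone, trifluoromethoxy in place of hydrogen on an aromatic carbon, para to a large group, gives a 3.3-fold higher number from compound 2 to compound 3 (0.52 log units; beyond the scatter), the first direct reading of this change, which shows that on the methyl-bearing core the phenyl to 4-(trifluoromethoxy)phenyl change weakens growth inhibition beyond the scatter. The second reading concerns the core: methyl in place of hydrogen on an aromatic carbon gives a 9.1-fold lower number from compound 1 to compound 3 (0.96 log units; beyond the scatter), also beyond the scatter, so with trifluoromethoxy held in place the methyl-bearing compound is the stronger inhibitor of growth, and the high number of compound 1 cannot be laid to trifluoromethoxy alone. Nothing measured here accounts for either step.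

Going by these compounds, whether a fluorine atom, a methoxy group, an amine or a carboxylic acid at the same place would shift the number in the same direction remains open. Equally open, on these data alone, is whether methyl has a comparable effect when hydrogen stands in place of trifluoromethoxy, and whether a longer chain such as ethyl on the core would go further.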